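The source may hold more compounds than are shown below. What is called first, only, known or untested is meant among the compounds shown, and "the series" means these compounds.

Compound 1 `CC(C)=CCCC1=CC[C@@H](C(=O)N(C)C)[C@H](c2ccccc2)C1` and compound 2 `CC1(C)CCCC2=C1C[C@H](C(=O)O)[C@@H](c1ccccc1)C2` share one core, and neither yields a number in an assay on isolated protein for inhibition of Apoptosis regulator Bcl-2 (Homo sapiens), read by fluorescence polarization, with stated times of 5 min and 10 min; a lower number here means a stronger inhibitor, a higher number a weaker inhibitor. In this assay compound 1 reaches only the limit > 23000 nM. Compound 2 likewise stops at the limit > 23000 nM in this assay. Both therefore sit at the limit of > 23000 nM in this assay, at which 2 of the 2 values shown sit, so compound 1 cannot be ranked against any measured neighbour. Compound 3 `CC(C)=CCCC1=CC[C@@H](C(=O)Nc2ccc(O)cc2)[C@H](c2ccccc2)C1` carries (4-hydroxyphenyl)amino in place of dimethylamino on a carbonyl carbon, in words (4-hydroxyphenyl)amino in place of dimethylamino on a carbonyl carbon. Among the compounds with values here, no measured step covers such a change; a gain is conceivable, but a further limit looks more probable. For compound 3 the estimate is 20000 nM, range 5000 nM to 60000 nM. The step of an at least 1.1-fold lower number from compound 1 to compound 3 (0.06 log units; that floor lies within the scatter) is expected to stay within the scatter.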

Compound 3, inhibition constant: > 23000 nM
Compound 3 ended at the assay's limit; the forecaster's own chance of this, stated with the estimate: 60%; at least 1.1-fold (0.06 log units) between middle value and limit.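

Compound 1 and compound 3 both stop at a limit of the assay, so no step can be read between them: the limit of > 23000 nM in this assay, at which 3 of the 3 values shown sit.

The compounds shown leave open whether any change on the shared core gives a measurable inhibition constant in this assay.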